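Removing one chloro from the saturated-linker dichlorophenyl amide

A few compounds are considered here, and "the series" means these few. Any claim that something is new, unique, unknown or untested is made for them only; others in the source may bear on it.

Measured so far:
compound 1 `O=C(CCCc1ccc(Cl)c(Cl)c1)Nc1nc2ccccc2c(=O)s1` — > 1500 nM in an assay on membranes from brain for displacement of a labelled ligand from adenosine receptor A1 (Rattus norvegicus), read by scintillation counting, with a stated time of 90 min; on this read-out lower numbers stand for stronger inhibition and higher numbers for weaker inhibition
compound 2 `O=C(C/C=C/c1cccc(Cl)c1)Nc1nc2ccccc2c(=O)s1` — 11.4 nM in this assay

In this assay compound 1 gives > 1500 nM, which is a limit of the assay and not a number, so compound 1 cannot be placed on the scale; of the two values shown it sits at the limit itself (the limit of > 1500 nM in this assay, at which 1 of the 2 values shown sits). In this assay compound 2 gives 11.4 nM, a real number on the potent side of the scale.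

Compound 3 `O=C(CCCc1cccc(Cl)c1)Nc1nc2ccccc2c(=O)s1` is not yet measured. It comes from compound 1 by hydrogen in place of chloro on an aromatic carbon; cut one bond further out, the change reads 3,4-dichlorophenyl to 3-chlorophenyl. Among the compounds with values here, no step between measured compounds covers this change, and no line of data ascribes an effect to the chloro that leaves. Compound 3 shares the 3-chlorophenyl with compound 2, but the two are otherwise not a listed pair and only their values can be compared once known.

The step is expected to go toward stronger binding, an at least 1.8-fold lower number from compound 1 to compound 3 (0.27 log units; that floor lies within the scatter), though with wide uncertainty and a fair chance of another limit. Compound 3 is estimated at 800 nM in this assay, within 100 nM to 5000 nM.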

Compound 3, inhibition constant: 898 nM
Compound 3: middle estimate off by 1.1-fold (0.05 log units), on the low side; the measured number falls inside the stated range.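

In this assay compound 1 gives > 1500 nM, a limit of the assay and not a number: the limit of > 1500 nM in this assay, at which 1 of the 3 values shown sits.

Hydrogen in place of chloro on an aromatic carbon, ortho to a chloro group, gives an at least 1.6-fold lower number from compound 1 to compound 3 (0.22 log units; that floor lies within the scatter); this is a floor, so the true size of the step cannot be read and may be larger. Within the data shown here, with the chloro gone, compound 3 gives 898 nM, the first real number for a compound with the saturated linker, and this shows that the 3,4-dichlorophenyl is not needed for a value on the scale.

From the compounds shown here alone, what a fluoro, a methyl or a methoxy group would do in place of the chloro that remains on the 3-chlorophenyl stays open, as does the effect of removing that chloro to leave a plain phenyl. Equally open, going by these compounds, is how a shorter or longer chain would behave with this 3-chlorophenyl, and whether any such change would carry the saturated series further along the scale.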